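From cyclohexyl to piperidin-3-yl on a shared core

The compounds below may be only part of what the source reports. "The series", "measured", "known", "first", "only" and "open" are said of these compounds alone.

In a functional assay on cells (Homo sapiens), read by thymidine incorporation (on this read-out lower numbers stand for stronger inhibition and higher numbers for weaker inhibition), compound 1 `COc1cc(NCc2cccnc2)n2ncc(Br)c2n1` gives 2000 nM. Going by the values given here, compound 2 `Brc1cnn2c(NCc3cccnc3)cc(C3CCCCC3)nc12` gives 200 nM, the lower of the two numbers measured so far. Among the compounds with values here, the single measured step, a 10-fold lower number from compound 1 to compound 2 (1.00 log units; beyond the scatter), is a replacement of methoxy by cyclohexyl on an aromatic carbon, and it lies beyond the scatter.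

Compound 3 `Brc1cnn2c(NCc3cccnc3)cc(C3CCCNC3)nc12` has not yet been measured. It differs from compound 2 at that same aromatic carbon: piperidin-3-yl in place of cyclohexyl on an aromatic carbon. This is piperidin-3-yl in place of cyclohexyl on an aromatic carbon. Within the data shown here, only the step of a 10-fold lower number from compound 1 to compound 2 (1.00 log units; beyond the scatter) bears on this change, and only indirectly. It shows that the number can move with the group at this place, but it involves no ring with a hetero atom, so the data offer no firm direction for the new change. The expected change is therefore small, and the estimated step, a 1.3-fold lower number from compound 2 to compound 3 (0.12 log units; within the scatter), stays within the scatter. The estimate for compound 3 is 150 nM, with an expected range of 40 nM to 700 nM.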

Compound 3, half-maximal inhibitory concentration: 60 nM
Compound 3: the middle estimate sits 2.5-fold (0.40 log units) above what was measured; low and high end bracket the measured number.
By their numbers in this assay, from the lowest: compound 3; then compound 2; then compound 1.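

In this assay, replacing the carbon-only ring of cyclohexyl with the piperidin-3-yl ring, also six-membered and non-aromatic, gives a 3.3-fold lower number from compound 2 to compound 3 (0.52 log units; beyond the scatter), so at this aromatic carbon a ring nitrogen with its hydrogen-bond donor and acceptor goes with a further drop in the number rather than a loss. Measured against the methoxy starting point, the change amounts to a 33-fold lower number from compound 1 to compound 3 (1.52 log units; beyond the scatter), which makes compound 3 the most potent of the three, with its steps to both others beyond the scatter. The data show only that this position responds to a single atom change within a ring of the same size, and no measurement bears on the reason for the drop.

The compounds shown leave open whether the ring nitrogen must sit where it does in piperidin-3-yl, as a comparison with piperidin-4-yl would show, and whether its hydrogen matters, as a 1-methylpiperidin-3-yl group would show. They also leave open whether the ring itself is needed, or whether an open-chain amine such as aminopropyl at the same carbon would serve as well.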